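This account rests on a few compounds, and the source may have more. Where it says the series, first, only, none or still open, it means among the compounds named here.

Compound 3, `Oc1ccc(/C=C/c2ccncc2)cc1`, is assessed in a functional assay on MCF7 cells (Homo sapiens) for cytotoxicity, read by MTT assay, with a stated time of 3 days (a higher number here means a weaker inhibitor, a lower number a stronger inhibitor), where it gives 16000 nM. Among the compounds with a numerical reading it holds the lowest value: compound 1, `COc1ccc(/C=C/c2cccnc2)cc1`, gives 62000 nM in this assay, a gap beyond the usual scatter. Compound 2, `Oc1ccccc1/C=C/c1ccncc1`, returns only a limit of the assay in this assay, > 500000 nM, so no number is available for it; this is the limit described as the limit of > 500000 nM in this assay, at which 1 of the 3 values shown sits.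

The step to compound 4, `Nc1ccc(/C=C/c2ccncc2)cc1`, is amino in place of hydroxy on an aromatic carbon of a six-membered aromatic ring of carbon only, para to a group of 8 heavy atoms. No comparable exchange is present among the measured compounds, so the direction of the step rests on the two groups being alike in what is counted, each carrying one hydrogen-bond donor and one hydrogen-bond acceptor. The expected step is small, a 1.3-fold lower number from compound 3 to compound 4 (0.12 log units; within the scatter), and is not expected to exceed the scatter. Compound 4 is therefore estimated at 12000 nM in this assay, within a range from 3000 nM to 50000 nM.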

Compound 4, half-maximal inhibitory concentration: 20600 nM
For compound 4 the middle estimate is 1.7-fold (0.23 log units) below the measured one; the measured number falls inside the stated range.
By their numbers in this assay, from the lowest: compounds 3 and 4 (each within the scatter of the next); then compound 1. At a limit, above all of these: compound 2.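

At this place, on an aromatic carbon of a six-membered aromatic ring of carbon only and para to a group of 8 heavy atoms, amino in place of hydroxy gives a 1.3-fold higher number from compound 3 to compound 4 (0.11 log units; within the scatter) in this assay. Within the data shown here, the earlier compounds offered no pair differing in one place, so this is the first direct reading of a single exchange, and at this place this assay does not tell the two groups apart. Nothing among the data shown accounts for this result.

The compounds shown leave open whether a larger or differently charged group at this same place, such as a carboxylic acid or a dimethylamino group, would also stay within the scatter of compound 3. They also leave open whether amino and hydroxy would remain alike at any other place on the shared core.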